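Ester Side Chain Swap on a Dihydropyridine Calcium Channel Blocker

A few compounds are considered here, and "the series" means these few. Any claim that something is new, unique, unknown or untested is made for them only; others in the source may bear on it.

Measured so far:
Compound 1 `CCOC(=O)C1=C(C)NC(COC)=C(C(=O)OC)C1c1cccc([N+](=O)[O-])c1` gives 14 nM
Compound 2 `CCOC(=O)C1=C(C)NC(C)=C(C(=O)OCCOC)C1c1cccc([N+](=O)[O-])c1` gives 16 nM

Both compounds were tested in a functional assay on HEK293 cells for antagonist activity at Voltage-dependent L-type calcium channel subunit alpha-1C (Oryctolagus cuniculus), read by FLIPR; a lower number here means a stronger inhibitor, a higher number a weaker inhibitor. Compound 1 gives 14 nM, and compound 2 gives 16 nM. Compound 2 holds the higher of the two numbers, but the gap to compound 1 is small and lies within the usual scatter of repeated measurements, so the two compounds cannot be told apart on these figures.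

Compound 3 `CCOC(=O)C1=C(C)NC(C)=C(C(=O)OCc2ccc([N+](=O)[O-])cc2)C1c1cccc([N+](=O)[O-])c1` has not yet been measured. It differs from compound 2 in one place: 4-nitrophenyl in place of methoxymethyl on a saturated chain carbon bound to an oxygen next to a carbonyl group. The shared core, the nitrophenyl ring attached to it and the other ester are unchanged; only the group on the second ester is swapped. Among the compounds with values here, no step between two measured compounds describes such an exchange, so there is nothing to copy from. Variation of this ester group is expected to leave the potency in a similar range, with at most a modest weakening. Compound 3 is therefore expected to show a step of a 1.6-fold higher number from compound 2 to compound 3 (0.19 log units; within the scatter), giving an estimated value of 25 nM with a range from 6 nM to 100 nM.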

Compound 3, half-maximal inhibitory concentration: 130 nM
Compound 3: the middle estimate sits 5.2-fold (0.72 log units) below what was measured, and the stated range ends below it.
By their numbers in this assay, from the lowest: compounds 1 and 2 (each within the scatter of the next); then compound 3.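

In this assay, replacing the 2-methoxyethyl group on the ester with 4-nitrobenzyl gives an 8.1-fold higher number from compound 2 to compound 3 (0.91 log units; beyond the scatter), so what this ester carries does matter for the potency of these compounds. The change swaps an open chain with no ring for a group with more heavy atoms and a six-membered aromatic ring, and the weakening this brings lies beyond the scatter of the measurement, although compound 3 at 130 nM still inhibits the channel. No measurement in hand explains this step, so its cause remains unknown.

The compounds shown leave open whether the step follows the aromatic ring, the nitro group on that ring or simply the greater number of heavy atoms, as all three change together between compound 2 and compound 3. A plain benzyl ester, which keeps the ring and has no nitro group, and a longer chain such as 3-methoxypropyl would be the comparisons that could begin to pull these apart.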